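The source may hold more compounds than are shown below. What is called first, only, known or untested is meant among the compounds shown, and "the series" means these compounds.

Working notes on the series, read in a functional assay on NCI-H1581 cells (Homo sapiens) for antiproliferative activity, read by CCK-8 assay, with a stated time of 72 h; a lower number here means a stronger inhibitor, a higher number a weaker inhibitor. Compound 1 (`COc1cc(OC)c(Cl)c(-c2ccc3c(NC(=O)c4ccc(N5CCN(C(C)C)CC5)cc4)n[nH]c3n2)c1Cl`) gives 1.4 nM, compound 2 (`COc1cc(OC)c(Cl)c(-c2ccc3c(NC(=O)c4ccc(N5CCN(C6CCC6)CC5)cc4)n[nH]c3n2)c1Cl`) gives 2.3 nM, and compound 3 (`C=CCN1CCN(c2ccc(C(=O)Nc3n[nH]c4nc(-c5c(Cl)c(OC)cc(OC)c5Cl)ccc34)cc2)CC1`) gives 3.3 nM. Compound 3 stands at the upper end of these three numbers. The data show a 2.4-fold higher number from compound 1 to compound 3 (0.37 log units; beyond the scatter) and a 1.4-fold higher number from compound 2 to compound 3 (0.16 log units; within the scatter).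

Compound 4 (`COc1cc(OC)c(Cl)c(-c2ccc3c(NC(=O)c4ccc(N(C)CCN(C)C)cc4)n[nH]c3n2)c1Cl`) is not yet measured. Its change is (2-(dimethylamino)ethyl)(methyl)amino in place of 4-allylpiperazin-1-yl on an aromatic carbon. For the measured compounds named here, the entering group has no ring, and no measured compound lacks the six-membered non-aromatic ring, so no step tests this change directly. The measured steps bear on it only indirectly, since each changes just the group on an amine nitrogen in a ring. They stay small, as in a 1.6-fold higher number from compound 1 to compound 2 (0.22 log units; within the scatter), and the largest is the modest step from allyl to isopropyl seen above. In this assay, going by the values given here, no step clearly beyond the scatter is expected, with a lean towards a higher number. The expected step is a 1.8-fold higher number from compound 3 to compound 4 (0.26 log units; within the scatter). For compound 4 the estimate is 6 nM, with an expected range of 2 nM to 20 nM.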

Compound 4, half-maximal inhibitory concentration: 11 nM
For compound 4 the middle estimate is 1.8-fold (0.26 log units) below the measured one, and the stated range covers the measured number.
By their numbers in this assay, from the lowest: compounds 1, 2 and 3 (each within the scatter of the next, the first and the last beyond it); then compound 4.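

In this assay, the ring-free (2-(dimethylamino)ethyl)(methyl)amino group on this aromatic carbon costs activity against each compound carrying a six-membered non-aromatic ring (a 3.3-fold higher number from compound 3 to compound 4 (0.52 log units; beyond the scatter); a 4.8-fold higher number from compound 2 to compound 4 (0.68 log units; beyond the scatter); a 7.9-fold higher number from compound 1 to compound 4 (0.90 log units; beyond the scatter)). Each of these steps lies beyond the scatter and is modest, so this position accepts the open chain but with a clear loss, which the changes on the ring nitrogen alone had not shown. No data on hand account for this loss.

The compounds shown do not separate the removal of the ring from the change in the groups on the nitrogens. A longer chain between the two amine nitrogens, or a morpholine ring at this place, would bear on that question.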